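Removing the fluoromethyl group: expectation for compound 4

A few compounds are considered here, and "the series" means these few. Any claim that something is new, unique, unknown or untested is made for them only; others in the source may bear on it.

For the measured compounds named here, in a functional assay on HeLa cells (Homo sapiens) for cytotoxicity, read by WST assay, with a stated time of 48 h (on this read-out lower numbers stand for stronger inhibition and higher numbers for weaker inhibition), compound 2 `COc1cc(C(c2ccc(O)c(OC)c2)[C@H](C)[C@H](C)CF)ccc1O` gives 75000 nM, the only number in this set. Compound 1 `COc1cc(C(c2ccc(O)c(OC)c2)[C@@H](C)[C@H](C)CO)ccc1O` returns only a limit of this assay, > 100000 nM. Compound 3 `COc1cc(C(c2ccc(O)c(OC)c2)[C@H](C)[C@H](C)CO)ccc1O` likewise returns only a limit, > 100000 nM. Because of the limit of > 100000 nM in this assay, at which 2 of the 3 values shown sit, the step of an at least 1.3-fold lower number from compound 1 to compound 2 (0.12 log units; that floor lies within the scatter) can only be read as a floor, and the same holds for an at least 1.3-fold higher number from compound 2 to compound 3 (0.12 log units; that floor lies within the scatter). Compounds 1 and 3 carry the same atoms and bonds and differ only in configuration as drawn, and the step that the two limits leave unreadable from compound 1 to compound 3 cannot be sized because of the fact that compounds 1 and 3 differ only in the configuration as drawn.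

Compound 4 `COc1cc(C(c2ccc(O)c(OC)c2)[C@@H](C)C(C)C)ccc1O` has not yet been measured in this assay. 1,2-dimethylpropyl in place of 2-(fluoromethyl)-1-methylpropyl on a saturated chain carbon bound to two aromatic carbons The measured steps that bear on this change are the two exchanges of hydroxy for fluoro on the same chain, both floors whose size lies within the scatter, so nothing steep is expected here either. Compound 4 is estimated at 50000 nM, with a range from 15000 nM to 150000 nM. The step of a 1.5-fold lower number from compound 2 to compound 4 (0.18 log units; within the scatter) is therefore the expected outcome, carrying a fair chance that this assay returns only a limit again.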

Compound 4, half-maximal inhibitory concentration: 19000 nM
Compound 4: middle estimate off by 2.6-fold (0.42 log units), on the high side; the range from low to high includes it.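

In this assay, for the compounds shown here, the chain carrying neither fluoro nor hydroxy gives the first step at this position that is readable beyond the scatter: a 3.9-fold lower number from compound 2 to compound 4 (0.60 log units; beyond the scatter). Against the two hydroxy compounds the same change gives an at least 5.2-fold lower number from compound 3 to compound 4 (0.72 log units; beyond the scatter) and an at least 5.2-fold lower number from compound 1 to compound 4 (0.72 log units; beyond the scatter), which makes compound 4 the lowest number of the four, with 1,2-dimethylpropyl on the saturated chain carbon bound to two aromatic carbons. The last two steps are only floors, and their true size may be larger, because each starts from a compound that returns no number: the limit of > 100000 nM in this assay, at which 2 of the 4 values shown sit.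

On these data alone, the step between compound 1 and compound 3 cannot be read, and what the configuration at this chain carbon contributes on its own stays open. Also open, as far as these compounds go, is whether a longer chain, or an amine in place of the fluoro or hydroxy on this chain, would extend the step seen with 1,2-dimethylpropyl or reverse it.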